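Lengthening the Acid Chain on the Shared Core

The compounds below may be only part of what the source reports. "The series", "measured", "known", "first", "only" and "open" are said of these compounds alone.

Three compounds share one core and differ in the arm that carries the acid. In an assay on CV-1 cells for agonist activity at thyroid hormone receptor beta (Homo sapiens), read by reporter gene assay, with a stated time of 10 h (on this read-out higher numbers stand for an effect only at larger amounts of compound and lower numbers for an effect already at smaller amounts), compound 1 `Cc1ccc(NC(=O)CC(=O)O)c2ccn(Cc3ccc(O)c(C(C)C)c3)c12` gives 3100 nM. Compound 2 `Cc1c(CCCCC(=O)O)c2ccccc2n1Cc1ccc(O)c(C(C)C)c1` gives 62 nM, and compound 3 `Cc1c(CC(=O)O)c2ccccc2n1Cc1ccc(O)c(C(C)C)c1` gives 150 nM, so compound 3 stands second highest of the three numbers, closer to compound 2 than to compound 1. For the measured compounds named here, the only measured step that bears on the new compound is a 2.4-fold higher number from compound 2 to compound 3 (0.38 log units; beyond the scatter), a modest rise when the chain is cut short. Compound 4 `Cc1c(CCC(=O)O)c2ccccc2n1Cc1ccc(O)c(C(C)C)c1` carries carboxymethyl in place of carboxy on a saturated chain carbon bound to an aromatic carbon, putting one carbon back into the chain and partly reversing that shortening. A modest fall in this assay is therefore expected, smaller than that measured step. Compound 4 is estimated at 100 nM, within 40 nM to 250 nM, an expected step of a 1.5-fold lower number from compound 3 to compound 4 (0.18 log units; within the scatter).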

Compound 4, half-maximal effective concentration: 37 nM
For compound 4 the middle estimate is 2.7-fold (0.43 log units) above the measured one, outside the stated range (below it).
By their numbers in this assay, from the lowest: compounds 4 and 2 (each within the scatter of the next); then compound 3; then compound 1.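

Putting one carbon back into the arm of compound 3 does more than the earlier shortening step suggested, giving a 4.1-fold lower number from compound 3 to compound 4 (0.61 log units; beyond the scatter) in this assay. The 2-carboxyethyl arm already matches the longer arm of compound 2, with a 1.7-fold lower number from compound 2 to compound 4 (0.22 log units; within the scatter), so among these three compounds, extending the chain past 2-carboxyethyl brings no change beyond the scatter. No available evidence explains why this one added carbon counts for so much. Still open, from the compounds shown here alone, is whether a chain longer than that of compound 2, or an amine in place of the carboxylic acid, would keep this level of effect.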